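This account rests on a few compounds, and the source may have more. Where it says the series, first, only, none or still open, it means among the compounds named here.

Compound 1 `CCN(CC)S(=O)(=O)c1ccc(S(=O)(=O)N2CCC[C@@H](C(=O)N3CCC(OC)CC3)C2)cc1` gives 140 nM in a functional assay on MIA PaCa-2 cells (Homo sapiens) for inhibition, read by MTT assay, with a stated time of 7 days; a lower number here means a stronger inhibitor, a higher number a weaker inhibitor.
Compound 2 `CCN(CC)S(=O)(=O)c1ccc(S(=O)(=O)N2CCC[C@@H](C(=O)NC3COC3)C2)cc1` gives 2340 nM in this assay.
Compound 3 `CCN(CC)S(=O)(=O)c1ccc(S(=O)(=O)N2CCC[C@@H](C(=O)NC3CCOCC3)C2)cc1` gives 3770 nM in this assay.

Compound 3 has the highest number of the three; its gap to compound 2 lies within the scatter, while compound 1 sits far lower. Compound 4 `CCN(CC)S(=O)(=O)c1ccc(S(=O)(=O)N2CCC[C@@H](C(=O)N3CCC(COC)CC3)C2)cc1` differs from compound 3 in one place: 4-(methoxymethyl)piperidin-1-yl in place of (oxan-4-yl)amino on a carbonyl carbon. For the measured compounds named here, the only measured steps that bear on this are those leaving compound 1, where a tertiary amide on the shared core became a secondary one: a 17-fold higher number from compound 1 to compound 2 (1.22 log units; beyond the scatter) and a 27-fold higher number from compound 1 to compound 3 (1.43 log units; beyond the scatter). Compound 4 reverses that kind of change, so a large fall in number is expected in this assay, landing near compound 1; the estimated step is a 19-fold lower number from compound 3 to compound 4 (1.28 log units; beyond the scatter). Compound 4 is therefore expected to give 200 nM, with a range of 60 nM to 700 nM.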

Compound 4, half-maximal inhibitory concentration: 250 nM
Compound 4: middle estimate off by 1.3-fold (0.10 log units), on the low side, within the range that was stated.
By their numbers in this assay, from the lowest: compounds 1 and 4 (each within the scatter of the next); then compounds 2 and 3 (each within the scatter of the next).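

Compound 4 shows that the large drop seen with compound 1 is not peculiar to its 4-methoxypiperidin-1-yl group: a second piperidine amide also lies well under the secondary amides (a 15-fold lower number from compound 3 to compound 4 (1.18 log units; beyond the scatter); a 9.4-fold lower number from compound 2 to compound 4 (0.97 log units; beyond the scatter)). Methoxymethyl in place of methoxy on a saturated ring carbon stays within the scatter (a 1.8-fold higher number from compound 1 to compound 4 (0.25 log units; within the scatter)), so this site tolerates that small extension. No evidence here explains these differences.

From the compounds shown here alone, it remains open whether the ether oxygen matters at all. An unsubstituted piperidin-1-yl amide, or a hydroxyl, an amine or a carboxylic acid in place of the methoxy, would test this.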